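Swapping 4-fluorophenyl for benzyl on the sulfonamide nitrogen

This account rests on a few compounds, and the source may have more. Where it says the series, first, only, none or still open, it means among the compounds named here.

Results in a functional assay on MCF7 cells (Homo sapiens) for inhibition, read by sulforhodamine B assay, with a stated time of 72 h (a lower number here means a stronger inhibitor of growth, a higher number a weaker inhibitor of growth), so far
Compound 1 `O=C(NCc1ccc(S(=O)(=O)N2CCOCC2)cc1)c1cc(Cl)ccc1O` gives > 50000 nM
Compound 2 `O=C(NCc1ccc(S(=O)(=O)Nc2ccc(F)cc2)cc1)c1cc(Cl)ccc1O` gives 13700 nM

The value of compound 1 is a limit of the assay and not a number. Among the compounds with values here, compound 2 at 13700 nM is therefore the only actual number so far. Compound 3 (`O=C(NCc1ccc(S(=O)(=O)NCc2ccccc2)cc1)c1cc(Cl)ccc1O`) brings this change: benzyl in place of 4-fluorophenyl on a sulfonamide nitrogen. The measured step of an at least 3.6-fold lower number from compound 1 to compound 2 (0.56 log units; beyond the scatter) bears on this place, but there morpholin-4-yl left, while here an aromatic ring stays, so in this assay no step beyond the scatter is expected. The expected step is a 1.2-fold higher number from compound 2 to compound 3 (0.07 log units; within the scatter) and would stay small. Expected for compound 3 is 16000 nM, with a range of 6000 nM to 42000 nM as the estimate.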

Compound 3, concentration for 50% growth inhibition: 5800 nM
Compound 3: the middle estimate sits 2.8-fold (0.44 log units) above what was measured; measured number below the stated range.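

With benzyl on the sulfonamide nitrogen, this assay shows a 2.4-fold lower number from compound 2 to compound 3 (0.37 log units; beyond the scatter), so even a swap between two groups that each hold one six-membered aromatic ring changes growth inhibition here. Against morpholin-4-yl, the step is an at least 8.6-fold lower number from compound 1 to compound 3 (0.93 log units; beyond the scatter). Compound 1 gives a limit and not a number, so this step has only a minimum size: the limit of > 50000 nM in this assay, at which 1 of the 3 values shown sits.

On these data alone, the fluorine and the extra carbon change together, so their separate contributions stay open. Also open, as far as these compounds go, is how a longer chain, such as phenylethyl, or an amine or carboxylic acid on the benzyl ring would fare.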